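Chloro to methoxy on the anilide, across two cinnamate cores

The source may report more compounds than this note shows. Statements on the series, on what has been measured and on what is new or still open speak of the compounds shown alone.

Compound 2 `COc1cc(/C=C/C(=O)OCC(=O)Nc2ccc(Cl)cc2)cc(OC)c1OCc1ccc(Cl)c(Cl)c1` and compound 1 `COc1ccc(NC(=O)COC(=O)/C=C/c2cc(OC)c(OCc3ccc(Cl)c(Cl)c3)c(OC)c2)cc1` share one core, while compound 3 `O=C(COC(=O)/C=C/c1ccc(O)c(O)c1)Nc1ccc(Cl)cc1` and the unmeasured compound 4 `COc1ccc(NC(=O)COC(=O)/C=C/c2ccc(O)c(O)c2)cc1` share another. The difference between the two cores is not broken down here. In a functional assay on CNE cells (Homo sapiens) for cytotoxicity, read by MTT assay, with a stated time of 72 h (a higher number here means a weaker inhibitor, a lower number a stronger inhibitor), compound 2 gives > 200000 nM, which is a limit of the assay and not a number. Compound 1 likewise gives > 200000 nM in this assay, again a limit. The change from compound 2 to compound 1 is methoxy in place of chloro on an aromatic carbon, and its step that the two limits leave unreadable from compound 2 to compound 1 cannot be read because both values rest on (the limit of > 200000 nM in this assay, at which 2 of the 3 values shown sit). For the measured compounds named here, compound 3 gives 89600 nM in this assay, the only number in the set. Compound 4 carries the same change, (methoxy in place of chloro on an aromatic carbon), on the other core. The measured instance of this change left no readable step, so there is no size to carry over. The expected step for compound 4 is therefore a 1.1-fold higher number from compound 3 to compound 4 (0.05 log units; within the scatter), kept small and with wide uncertainty. The estimate for compound 4 in this assay is 100000 nM, between 35000 nM and 250000 nM.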

Compound 4, half-maximal inhibitory concentration: > 200000 nM
Compound 4: only a limit was reported; the forecaster's own chance of this, stated with the estimate: 30%; at least 2.0-fold (0.30 log units) between middle value and limit.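

In this assay compound 4 gives > 200000 nM, which is a limit of the assay and not a number. As far as these compounds go, on the core of compound 3, the change from 4-chlorophenyl to 4-methoxyphenyl therefore gives an at least 2.2-fold higher number from compound 3 to compound 4 (0.34 log units; beyond the scatter), a loss of activity beyond the scatter whose full size stays unknown. The same change from compound 2 to compound 1 cannot be read, so the step on one core cannot be set against the step on the other, and this pair neither shows nor rules out that the change carries between cores, because the values rest on a shared ceiling: the limit of > 200000 nM in this assay, at which 3 of the 4 values shown sit.

The compounds shown leave open whether a different group in place of the chloro of compound 3, such as an amine, a nitrile or a carboxylic acid, would give a lower number in this assay. They also leave open what the difference between the two cores contributes on its own.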